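Methyl on the fused ring: compound 3 to compound 4

This account rests on a few compounds, and the source may have more. Where it says the series, first, only, none or still open, it means among the compounds named here.

compound 1 `Cc1ccc2nc(Cl)c(/C=N/n3cc(-c4ccccc4)nc3N)cc2c1`: 48100 nM in a functional assay on MDA-MB-231 cells (Homo sapiens) for cytotoxicity, read by MTT assay, with a stated time of 48 h; on this read-out higher numbers stand for weaker inhibition and lower numbers for stronger inhibition
compound 2 `Cc1ccc2nc(Cl)c(/C=N/n3cc(-c4ccc(Cl)cc4)nc3N)cc2c1`: 35200 nM
compound 3 `Nc1nc(-c2ccc3ccccc3c2)cn1/N=C/c1cc2ccccc2nc1Cl`: > 50000 nM, a limit only

Compound 3 gives no number in this assay, only the limit > 50000 nM, so it stands at the limit of > 50000 nM in this assay, at which 1 of the 3 values shown sits, rather than at a measured value. Compound 4 `Cc1ccc2nc(Cl)c(/C=N/n3cc(-c4ccc5ccccc5c4)nc3N)cc2c1` differs from compound 3 by methyl in place of hydrogen on an aromatic carbon. Within the data shown here, the single measured step, a 1.4-fold lower number from compound 1 to compound 2 (0.14 log units; within the scatter), concerns a substituent on the other aromatic ring and bears only loosely on this change; no step with a methyl on the fused ring has been measured. The expectation for this assay is therefore a step no larger than the scatter, a number no higher from compound 3 to compound 4 (the limit leaves the size open), with no clear direction. Compound 4 is estimated at 50000 nM, within a range from 25000 nM to 100000 nM, and a reported limit again is quite likely.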

Compound 4, half-maximal inhibitory concentration: 35600 nM
The estimate for compound 4 lay 1.4-fold (0.15 log units) above the measured number; the range from low to high includes it.
By their numbers in this assay, from the lowest: compounds 2, 4 and 1 (each within the scatter of the next). At a limit, above all of these: compound 3.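

Compound 3 has only a limit, so methyl in place of hydrogen on an aromatic carbon can be read in this assay only as a floor: an at least 1.4-fold lower number from compound 3 to compound 4 (0.14 log units; that floor lies within the scatter). With the methyl present, naphthalen-2-yl in place of 4-chlorophenyl gives a 1.0-fold higher number from compound 2 to compound 4 (0.00 log units; within the scatter), and naphthalen-2-yl in place of phenyl gives a 1.4-fold lower number from compound 1 to compound 4 (0.13 log units; within the scatter). Phenyl, 4-chlorophenyl and naphthalen-2-yl therefore stand within the scatter of each other on the methyl-bearing core.

Going by these compounds, whether the methyl itself shifts the number beyond the scatter stays open. Also open, on these data alone, is how a methoxy group or a carboxylic acid in place of that methyl would read in this assay.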